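Hydroxymethyl in place of methoxy on the fused ring

The source may report more compounds than this note shows. Statements on the series, on what has been measured and on what is new or still open speak of the compounds shown alone.

Compound 3 `CC#C[C@@H](CC(=O)O)c1ccc(OC[C@H]2COc3ccc(OC)cc3O2)cc1` gives 130 nM in a functional assay on HEK293 cells for agonist activity at Free fatty acid receptor 1 (Homo sapiens), read by fluorescence and calcium flux, with a stated time of 10 min (a higher number here means that more compound is needed for the effect, a lower number that less compound is needed), the second highest of the three numbers recorded. Compound 2 `CC#C[C@@H](CC(=O)O)c1ccc(OC[C@H]2COc3ccccc3O2)cc1` gives 90 nM, and the step of a 1.4-fold higher number from compound 2 to compound 3 (0.16 log units; within the scatter) lies within the scatter. Compound 1 `O=C(O)CC(c1ccc(OCC2COc3ccc(Cl)cc3O2)cc1)c1cnco1` gives 1030 nM; its gap to compound 3 lies beyond the scatter, but the two differ in more than one place, so no single step can be read from it. Compound 4 `CC#C[C@@H](CC(=O)O)c1ccc(OC[C@H]2COc3ccc(CO)cc3O2)cc1` differs from compound 3 by hydroxymethyl in place of methoxy on an aromatic carbon. Among the measured compounds shown here, no measured step covers this exact exchange; the only neighbouring step, hydrogen to methoxy at the same carbon, stayed within the scatter. Compound 4 is therefore expected at about 150 nM (range 60 nM to 400 nM). The expected step of a 1.2-fold higher number from compound 3 to compound 4 (0.06 log units; within the scatter) is estimated to stay within the scatter.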

Compound 4, half-maximal effective concentration: > 30000 nM
Compound 4 gave a limit, no number; the forecaster's own chance of this, stated with the estimate: 3%; middle value at least 200-fold (2.30 log units) away from the limit.
By their numbers in this assay, from the lowest: compounds 2 and 3 (each within the scatter of the next); then compound 1. At a limit, above all of these: compound 4.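

In this assay, swapping the methoxy for a hydroxymethyl on the aromatic carbon gives an at least 230-fold higher number from compound 3 to compound 4 (2.36 log units; beyond the scatter), and hydroxymethyl in place of hydrogen gives an at least 330-fold higher number from compound 2 to compound 4 (2.52 log units; beyond the scatter). The position therefore separates two groups with the same atoms, a sensitivity that hydrogen and methoxy, within the scatter of each other, did not reveal. Compound 4 stands at a limit of the assay, not at a number: the limit of > 30000 nM in this assay, at which 1 of the 4 values shown sits.

As far as these compounds go, whether the free hydroxyl or the chain carbon drives this step remains open. An ethyl, a methoxymethyl or an amine at this carbon would separate the two.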